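This account rests on a few compounds, and the source may have more. Where it says the series, first, only, none or still open, it means among the compounds named here.

Working notes on the series. Among the compounds with values here, compound 1, `O=C1NCCN1c1ccc(S(=O)(=O)Nc2ccc(Br)cc2)cc1`, is the reference point: in a functional assay on M21 cells (Homo sapiens) for antiproliferative activity, read by sulforhodamine B assay, with a stated time of 48 h (on this read-out lower numbers stand for stronger inhibition and higher numbers for weaker inhibition), compound 1 gives 130 nM, and this is the only number the series has in this assay so far. Compound 2, `CC(C)(C)c1cc(NS(=O)(=O)c2ccc(N3CCNC3=O)cc2)cc(C(C)(C)C)c1`, reaches only a limit in this assay, > 1000 nM, and the value is to be read as a limit rather than a measurement. That limit, (the limit of > 1000 nM in this assay, at which 1 of the 2 values shown sits), marks the edge of what the assay reports and leaves compound 2 without a numeric comparison to compound 1. Within the data shown here, no step between two measured compounds is available, so no measured change in this assay serves as a yardstick for what follows.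

Compound 3, `O=C1NCCN1c1ccc(S(=O)(=O)Nc2ccc(F)cc2)cc1`, is not yet measured. It differs from compound 1 by fluoro in place of bromo on an aromatic carbon; the shared core is untouched. With nothing measured for this kind of change, a modest step toward weaker inhibition in this assay from compound 1 to compound 3 is expected, a 3.1-fold higher number from compound 1 to compound 3 (0.49 log units; beyond the scatter), while a result within the scatter would not be surprising. Compound 3 is accordingly estimated at 400 nM, within 120 nM to 1500 nM.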

Compound 3, half-maximal inhibitory concentration: 230 nM
Beside the measured number, compound 3's estimate is 1.7-fold (0.24 log units) above it; low and high end bracket the measured number.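

In this assay, within the data shown here, fluoro in place of bromo on an aromatic carbon, para to a large group, gives a 1.8-fold higher number from compound 1 to compound 3 (0.25 log units; within the scatter) and so provides the first measured step, a first yardstick for changes at this position. On this read-out, compound 1 and compound 3 cannot be told apart, so 4-bromophenyl and 4-fluorophenyl read alike here, with the shared core untouched, and this exchange of one halogen for the other leaves no change beyond the scatter. Nothing at hand explains why these two halogens read alike.

The compounds shown leave open how an amine, a carboxylic acid, a methoxy group or a longer chain at this same place would read in this assay, so the step says nothing about groups other than these two halogens. They also leave open whether fluoro in place of bromo would read the same way on a different core, and this single step supports no broader pattern for the series.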